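Benzyl to methyl on compound 1

This account rests on a few compounds, and the source may have more. Where it says the series, first, only, none or still open, it means among the compounds named here.

Going by the values given here, in an ADME assay on HepG2 cells (Homo sapiens) for cytotoxicity, read by CellTiter-Glo and ATP content, with a stated time of 72 h (on this read-out lower numbers stand for an effect already at smaller amounts and higher numbers for an effect only at larger amounts of compound), compound 1 `CS(=O)(=O)c1ccc(C(=O)NCC(=O)N(Cc2ccccc2)Cc2ccccc2)cc1[N+](=O)[O-]` gives 11900 nM as the only actual number. Compound 2 `CCCN(C(=O)CN(C)C(=O)c1ccc(S(C)(=O)=O)c([N+](=O)[O-])c1)c1ccccc1` reads > 27000 nM as a limit. Compound 3 `CN(CC(=O)N(Cc1ccccc1)Cc1ccccc1)C(=O)c1ccc(S(C)(=O)=O)c([N+](=O)[O-])c1` reads > 27000 nM as a limit too. Among the compounds with values here, the single measured step of an at least 2.2-fold higher number from compound 1 to compound 3 (0.35 log units; beyond the scatter) lies at another place, yet it is the only guide and it runs upward. Relative to compound 1, compound 4 `CN(Cc1ccccc1)C(=O)CNC(=O)c1ccc(S(C)(=O)=O)c([N+](=O)[O-])c1` carries the difference hydrogen in place of phenyl on a saturated chain carbon bound to an amide-type nitrogen with hydrogen in place of phenyl on a saturated chain carbon bound to an amide-type nitrogen. Within the data shown here, no measured step covers this change directly. The expected size in this assay is a modest rise, an estimated 1.7-fold higher number from compound 1 to compound 4 (0.23 log units; within the scatter) towards higher numbers. Compound 4 is estimated at 20000 nM with an expected range from 9000 nM to 45000 nM in all.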

Compound 4, half-maximal effective concentration: > 27000 nM
Compound 4: a limit, no number; the forecaster's own chance of this, stated with the estimate: 45%; at least 1.3-fold (0.13 log units) between middle value and limit.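

In this assay, going by these compounds alone, benzyl to methyl on the amide-type nitrogen gives an at least 2.2-fold higher number from compound 1 to compound 4 (0.35 log units; beyond the scatter), the first reading at this place, and it runs the same way as an at least 2.2-fold higher number from compound 1 to compound 3 (0.35 log units; beyond the scatter). Compound 4 reads > 27000 nM, which is a limit, so this step has a floor but no measured size. Only compound 1 keeps an actual number: the limit of > 27000 nM in this assay, at which 3 of the 4 values shown sit.

On these data alone, whether a longer chain or an amine at this place would give a number under that limit stays open. No order among compound 2, compound 3 and compound 4 can be read.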